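Replacing Phenoxymethyl with Phenyl on a Carbonyl Carbon

This account rests on a few compounds, and the source may have more. Where it says the series, first, only, none or still open, it means among the compounds named here.

Of the compounds shown here, three have so far been tested in an assay on nucleic acid for inhibition of Nucleic Acid, read by fluorescence, tested at 100 uM; on this read-out higher numbers stand for more inhibition at the one concentration tested (going by the name of the read-out) and lower numbers for less inhibition. Compound 1 `CCOC(=O)C1CCCN(Cc2cn(C3CCCCC3OC(=O)COc3ccccc3)nn2)C1` gives 21%. Compound 2 `CC(C)CCN(C)Cc1cn(C2CCCCC2OC(=O)COc2ccccc2)nn1` gives 59%, the highest of the three numbers. Compound 3 `CCOC(=O)C1CCCN(Cc2cn(C3CCCCC3OC(=O)c3ccccc3)nn2)C1` gives 11%.

Compound 1 and compound 2 differ in their cores: isopentyl(methyl)amino in place of 3-(ethoxycarbonyl)piperidin-1-yl on a saturated chain carbon bound to an aromatic carbon. That difference goes with a change of a number 38 percentage points higher from compound 1 to compound 2 (beyond the scatter) in this assay.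

Compound 3 arises from compound 1 by a single change: phenyl in place of phenoxymethyl on a carbonyl carbon. In this assay the read-out moves a number 10 percentage points lower from compound 1 to compound 3 (within the scatter), a shift that stays within the usual spread of repeated measurements.

Compound 4 `CC(C)CCN(C)Cc1cn(C2CCCCC2OC(=O)c2ccccc2)nn1` has not yet been measured. It arises from compound 2 by the same change at the same place: phenyl in place of phenoxymethyl on a carbonyl carbon. Because the earlier step, a number 10 percentage points lower from compound 1 to compound 3 (within the scatter), lay within the scatter, the step from compound 2 to compound 4 is expected to be small as well, about a number 10 percentage points lower from compound 2 to compound 4 (within the scatter). On that basis compound 4 is estimated to give 49% in this assay, most likely between 30% and 68%.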

Compound 4, a percentage reported as inhibition, at one concentration (the size of the read-out at that concentration, not a potency): 26%
Estimate against measurement, compound 4: 23 percentage points above; measured number below the stated range.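

Moving from phenoxymethyl to phenyl on a carbonyl carbon does not give a step of the same size on both cores in this assay: the same change on two cores in this assay, a number 10 percentage points lower (within the scatter) from compound 1 to compound 3 and a number 33 percentage points lower (beyond the scatter) from compound 2 to compound 4, 23 percentage points apart, beyond the scatter of two such steps. On the core of compound 2 the change gives a number 33 percentage points lower from compound 2 to compound 4 (beyond the scatter), so a small step on the core of compound 1 did not predict a small step on another core in this series. This shows only that the size of the step differs on these two cores; it does not explain the difference, and two cores cannot give a rule for any third core.

The compounds shown leave open how the same change would behave with a different amine on the saturated chain carbon, such as morpholin-4-yl or dimethylamino. They also leave open what a 2-phenylethyl group on the carbonyl carbon would give, which would separate the longer chain of phenoxymethyl from its oxygen.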